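A few compounds are considered here, and "the series" means these few. Any claim that something is new, unique, unknown or untested is made for them only; others in the source may bear on it.

Working notes on the series. All three measured compounds share one core and differ only at the nitrogen on the aromatic ring. Compound 1 `COc1cccc(N(CCNC(C)=O)Cc2ccccc2)c1` gives 0.759 nM in an assay on NIH3T3 cells for displacement of a labelled ligand from melatonin receptor type 1B (Homo sapiens); a lower number here means a stronger inhibitor, a higher number a weaker inhibitor. Compound 2 `COc1cccc(N(C)CCNC(C)=O)c1` gives 0.646 nM in this assay. Compound 3 `COc1cccc(NCCNC(C)=O)c1` gives 7.41 nM in this assay. Compound 2 has the lowest number of the three, but a 1.2-fold lower number from compound 1 to compound 2 (0.07 log units; within the scatter) is within the scatter, so compound 1 and compound 2 cannot be ordered. Compound 3 stands apart: an 11-fold higher number from compound 2 to compound 3 (1.06 log units; beyond the scatter) and a 9.8-fold higher number from compound 1 to compound 3 (0.99 log units; beyond the scatter) both show a loss when hydrogen replaces methyl or benzyl on the nitrogen on the aromatic ring.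

Compound 4 `COc1cccc(N(C)CCCNC(C)=O)c1` differs from compound 2 by acetamidomethyl in place of acetamido on a saturated chain carbon, two bonds along the chain from a nitrogen on an aromatic ring. None of the three measured steps concerns this part of the molecule; each of them alters only the nitrogen on the aromatic ring. Among the measured compounds shown here, the measured set therefore holds no step that bears on the change from compound 2 to compound 4, and the expectation has to be wide. Without a comparable step, a modest rise in the number is expected, a 4.6-fold higher number from compound 2 to compound 4 (0.67 log units; beyond the scatter), with no change inside the range. Compound 4 is expected to give about 3 nM in this assay, estimated between 0.6 nM and 15 nM.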

Compound 4, inhibition constant: 2 nM
Compound 4: the middle estimate sits 1.5-fold (0.18 log units) above what was measured; measured number inside the range.
By their numbers in this assay, from the lowest: compounds 2 and 1 (each within the scatter of the next); then compound 4; then compound 3.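

In this assay, the change at this position gives a 3.1-fold higher number from compound 2 to compound 4 (0.49 log units; beyond the scatter), the only step shown that alters the chain rather than the nitrogen on the aromatic ring. It shows that this saturated chain carbon, two bonds along the chain from a nitrogen on an aromatic ring, also affects the number: compound 4 gives 2 nM, beyond the scatter of its parent. The swap is small on the computed count, from acetamido with 4 heavy atoms to acetamidomethyl with 5 heavy atoms, each with 1 hydrogen-bond donor, 1 hydrogen-bond acceptor, no ring and no net charge, and no measurement at hand speaks to the origin of the step.

The compounds shown leave open whether a longer chain carrying the same acetamido end would raise the number further or bring it back down, and whether the step keeps its size when benzyl or hydrogen stands on the nitrogen on the aromatic ring. They also leave open how an amine or a carboxylic acid would compare with acetamido at this place on the chain.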